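This account rests on a few compounds, and the source may have more. Where it says the series, first, only, none or still open, it means among the compounds named here.

Compound 3, with the structure `COc1cccc(NC(=O)CSc2nc(Nc3ccccc3)c3ccccc3n2)c1`, stands at the top of the three numbers recorded in a functional assay on NCI-H1975 cells (Homo sapiens) for inhibition, read by MTT assay, with a stated time of 72 h; a higher number here means a weaker inhibitor, a lower number a stronger inhibitor: compound 3 gives 19400 nM. Compound 2, `O=C(CSc1nc(Nc2ccccc2)c2ccccc2n1)Nc1cccc([N+](=O)[O-])c1`, gives 17900 nM, and the pair sits a 1.1-fold higher number from compound 2 to compound 3 (0.03 log units; within the scatter). Compound 1, `O=C(CSc1nc(Nc2ccccc2)c2ccccc2n1)Nc1cccc(F)c1`, gives 6790 nM, the lowest of the three, and the move a 2.9-fold higher number from compound 1 to compound 3 (0.46 log units; beyond the scatter) is the larger of the two steps that reach compound 3.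

Compound 4, `O=C(CSc1nc(Nc2ccccc2)c2ccccc2n1)Nc1ccc(C(F)(F)F)cc1`, differs from compound 3 in one place: 4-(trifluoromethyl)phenyl in place of 3-methoxyphenyl on an amide-type nitrogen. Within the data shown here, no measured step swaps one group for another in quite this way. Among the measured compounds shown here, the steps that bear on it are a 2.9-fold higher number from compound 1 to compound 3 (0.46 log units; beyond the scatter) and a 2.6-fold higher number from compound 1 to compound 2 (0.42 log units; beyond the scatter), both modest, and a 1.1-fold higher number from compound 2 to compound 3 (0.03 log units; within the scatter), which lies within the scatter. Since compound 1 sits lowest in this assay at 6790 nM, and compound 4 removes the methoxy that marked the higher values, a modest move downward is expected, of about a 2.2-fold lower number from compound 3 to compound 4 (0.33 log units; beyond the scatter). Compound 4 is therefore estimated to give 9000 nM, within a range from 3000 nM to 27000 nM.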

Compound 4, half-maximal inhibitory concentration: 11700 nM
The estimate for compound 4 lay 1.3-fold (0.11 log units) below the measured number; measured number inside the range.
By their numbers in this assay, from the lowest: compounds 1, 4, 2 and 3 (each within the scatter of the next, the first and the last beyond it).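

Compound 4 is the only one shown with 4-(trifluoromethyl)phenyl on the amide-type nitrogen, and in this assay it cannot be told apart from any of the other three: the steps (a 1.7-fold lower number from compound 3 to compound 4 (0.22 log units; within the scatter)), (a 1.5-fold lower number from compound 2 to compound 4 (0.18 log units; within the scatter)) and (a 1.7-fold higher number from compound 1 to compound 4 (0.24 log units; within the scatter)) all lie within the scatter. This change of group therefore gives no step beyond the scatter, unlike the replacements of fluoro by nitro (a 2.6-fold higher number from compound 1 to compound 2 (0.42 log units; beyond the scatter)) and by methoxy (a 2.9-fold higher number from compound 1 to compound 3 (0.46 log units; beyond the scatter)). Nothing available explains these values.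

What the compounds shown leave open is how this position would respond to an amine or a carboxylic acid on the phenyl ring, or to a longer chain in place of the ring. They also leave open whether any change to the shared core would shift the values further than these replacements do.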